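From Naphthalen-1-yl Ether to 2,3,4-Trifluorophenyl Ether

A few compounds are considered here, and "the series" means these few. Any claim that something is new, unique, unknown or untested is made for them only; others in the source may bear on it.

Compound 1 `CC(C)[C@H](NC(=O)COc1cccc2ccccc12)C(=O)N[C@@H](CC(=O)O)C(=O)COc1cccc2ccccc12` gives 19000 nM in a functional assay with Homo sapiens as the target; on this read-out higher numbers stand for weaker inhibition and lower numbers for stronger inhibition.
Compound 2 `CC(C)[C@H](NC(=O)COc1cccc2ccccc12)C(=O)N[C@@H](CC(=O)O)C(=O)COc1cc(F)ccc1F` gives 19700 nM.
Compound 3 `CC(C)[C@H](NC(=O)COc1cccc2ccccc12)C(=O)N[C@@H](CC(=O)O)C(=O)COc1c(F)cccc1F` reports only a limit, > 100000 nM.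

Compound 1 holds the lowest of the two plain numbers, with compound 2 within the scatter of it (a 1.0-fold higher number from compound 1 to compound 2 (0.02 log units; within the scatter)); the value of compound 3 is a limit, not a number (the limit of > 100000 nM in this assay, at which 1 of the 3 values shown sits). Compound 4 `CC(C)[C@H](NC(=O)COc1cccc2ccccc12)C(=O)N[C@@H](CC(=O)O)C(=O)COc1ccc(F)c(F)c1F` differs from compound 1 in one place: 2,3,4-trifluorophenyl in place of naphthalen-1-yl on an oxygen on a saturated carbon. Among the measured compounds shown here, the steps that bear on this are a 1.0-fold higher number from compound 1 to compound 2 (0.02 log units; within the scatter) and an at least 5.2-fold higher number from compound 1 to compound 3 (0.72 log units; beyond the scatter). The entering 2,3,4-trifluorophenyl is closer in kind to the 2,5-difluorophenyl of compound 2 than to the 2,6-difluorophenyl of compound 3, so a step near the scatter or slightly weaker is expected. Compound 4 is therefore estimated at 25000 nM (range 10000 nM to 80000 nM), a step of a 1.3-fold higher number from compound 1 to compound 4 (0.12 log units; within the scatter).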

Compound 4, half-maximal inhibitory concentration: 20600 nM
Compound 4: the middle estimate sits 1.2-fold (0.08 log units) above what was measured, and the stated range covers the measured number.
By their numbers in this assay, from the lowest: compounds 1, 2 and 4 (each within the scatter of the next). At a limit, above all of these: compound 3.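

In this assay, the two-ring naphthalen-1-yl gives way to the one-ring 2,3,4-trifluorophenyl with a 1.1-fold higher number from compound 1 to compound 4 (0.04 log units; within the scatter), and replacing 2,5-difluorophenyl gives a 1.0-fold higher number from compound 2 to compound 4 (0.02 log units; within the scatter). Replacing 2,6-difluorophenyl gives an at least 4.8-fold lower number from compound 3 to compound 4 (0.68 log units; beyond the scatter), so a ring with three fluorines keeps the level of compounds 1 and 2, and compound 3 is the exception among these ethers. The value of compound 3 is a limit, not a number: the limit of > 100000 nM in this assay, at which 1 of the 4 values shown sits.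

The compounds shown leave open how an unsubstituted phenyl or a pyridin-3-yl would behave on this oxygen.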